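Amide-nitrogen aryl variation: from compound 2 to compound 3

The source may hold more compounds than are shown below. What is called first, only, known or untested is meant among the compounds shown, and "the series" means these compounds.

Measured so far:
compound 1 `O=C(Nc1ccc([N+](=O)[O-])cc1)c1c(O)c2cccnc2n(-c2ccccc2)c1=O`: -7.6%
compound 2 `Cc1cccc(NC(=O)c2c(O)c3cccnc3n(-c3ccccc3)c2=O)c1`: 14.2%

In a functional assay on the whole organism for inhibition, with Rattus norvegicus as the target, read by paw edema, at a dose of 100 mg/kg by the oral route (a higher number here means more inhibition at the dose given (going by the name of the read-out), a lower number less inhibition), compound 2 gives 14.2%, the higher of the two numbers; compound 1 sits lower by a number 21.8 percentage points higher from compound 1 to compound 2 (beyond the scatter). Compound 3 `O=C(Nc1ccncc1)c1c(O)c2cccnc2n(-c2ccccc2)c1=O` is unmeasured; it differs from compound 2 by pyridin-4-yl in place of 3-methylphenyl on an amide-type nitrogen. Going by the values given here, the one measured step concerns a different exchange at the same amide-type nitrogen, so no step bears directly on this change. Among the compounds with values here, both numbers so far are small, so for compound 3 a step within the scatter is expected, a number 9.2 percentage points lower from compound 2 to compound 3 (within the scatter). The estimate for compound 3 in this assay is 5%, with a range from -15% to 25%.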

Compound 3, a percentage reported as inhibition, in the whole organism at one dose (the size of the read-out at that dose, not a potency): 34.9%
Compound 3: middle estimate off by 29.9 percentage points, on the low side, and the stated range ends below it.
By their numbers in this assay, from the lowest: compound 1; then compound 2; then compound 3.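

In this assay, pyridin-4-yl on the amide-type nitrogen gives a number 20.7 percentage points higher from compound 2 to compound 3 (beyond the scatter) and a number 42.5 percentage points higher from compound 1 to compound 3 (beyond the scatter) within this series. The ring with a hetero atom thus stands above both carbon-only aryl rings shown, and the choice of aryl group at this nitrogen clearly moves the read-out. Nothing available explains this gain. Still open, on these data alone, is whether pyridin-3-yl or pyridin-2-yl matches pyridin-4-yl, and whether a saturated amine ring such as piperidin-4-yl on this nitrogen keeps the inhibition.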